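This account rests on a few compounds, and the source may have more. Where it says the series, first, only, none or still open, it means among the compounds named here.

Measured in an ADME assay on HEK-293T cells (Homo sapiens) for cytotoxicity, read by resazurin assay, with a stated time of 16 h; a lower number here means a stronger inhibitor, a higher number a weaker inhibitor:

Compound 1 `OC[C@H]1O[C@@H](n2cnc3c(NC4CCCC4)nc(NC4CCCCCC4)nc32)[C@H](O)[C@@H]1O`: 167000 nM
Compound 2 `OC[C@H]1O[C@@H](n2cnc3c(NC4CCCCC4)nc(NC4CCCC4)nc32)[C@H](O)[C@@H]1O`: > 500000 nM

Compound 2 stands at > 500000 nM, which is a limit of this assay and not a number. Compound 3 `CCCCNc1nc(NC2CCCC2)nc2c1ncn2[C@@H]1O[C@H](CO)[C@@H](O)[C@H]1O` differs from compound 2 in one place: butyl in place of cyclohexyl on a nitrogen on an aromatic ring. Among the compounds with values here, no measured pair of compounds shows this change, and compound 1, at 167000 nM, is the only true number available for comparison. A shift beyond the usual scatter is therefore not expected in either direction. The expected step is a number no higher from compound 2 to compound 3 (the limit leaves the size open). The estimated value for compound 3 is 500000 nM, with an expected range of 200000 nM to 1000000 nM.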

Compound 3, half-maximal inhibitory concentration: > 500000 nM
Compound 3: no number, only a limit (the forecaster's own chance of this, stated with the estimate: 65%); the middle value lies on the limit itself.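

Compound 2 and compound 3 each give only a limit and not a number, so no step can be read between them: the limit of > 500000 nM in this assay, at which 2 of the 3 values shown sit.
On these data alone, whether butyl in place of cyclohexyl shifts the value in this assay stays open.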